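A few compounds are considered here, and "the series" means these few. Any claim that something is new, unique, unknown or untested is made for them only; others in the source may bear on it.

Measured compounds:
- compound 1, `COc1ccc(Nc2nc(N[C@H]3CC[C@H](N)CC3)nc3c2ncn3CCC(C)C)c(OC)c1`: 32900 nM
- compound 2, `CC(C)=CCn1cnc2c(Nc3cccc(Cl)c3)nc(N[C@H]3CC[C@H](N)CC3)nc21`: 13500 nM

In a functional assay on HCC827 cells (Homo sapiens) for inhibition, read by fluorescence, with a stated time of 72 h (on this read-out lower numbers stand for stronger inhibition of growth and higher numbers for weaker inhibition of growth), compound 1 gives 32900 nM, the higher of the two numbers recorded, so of these two it is the weaker inhibitor of growth. Compound 2, in this assay, gives 13500 nM, a lower number whose gap to compound 1 lies beyond the usual scatter of repeated measurements. Going by the values given here, compound 2 differs from compound 1 in more than one place, so the two values alone show only that the pair is not interchangeable.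

Compound 3, `CC(C)CCn1cnc2c(Nc3ccc(O)cc3)nc(N[C@H]3CC[C@H](N)CC3)nc21`, has not yet been measured. It differs from compound 1 in one place: 4-hydroxyphenyl in place of 2,4-dimethoxyphenyl on a nitrogen on an aromatic ring. The shared core and the chain on it stay as in compound 1. Among the compounds with values here, no single-change step between measured compounds is available to calibrate this exchange, so the expectation rests on the two values alone. The step of a 2.2-fold lower number from compound 1 to compound 3 (0.34 log units; beyond the scatter) is expected to run toward a lower number, modest in size and possibly not beyond the scatter. Compound 3 is estimated at 15000 nM, within a range of 4000 nM to 60000 nM.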

Compound 3, concentration for 50% growth inhibition: 14400 nM
Beside the measured number, compound 3's estimate is 1.0-fold (0.02 log units) above it; measured number inside the range.
By their numbers in this assay, from the lowest: compounds 2 and 3 (each within the scatter of the next); then compound 1.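

In this assay, going by these compounds alone, the exchange of 2,4-dimethoxyphenyl for 4-hydroxyphenyl on a nitrogen on an aromatic ring gives a 2.3-fold lower number from compound 1 to compound 3 (0.36 log units; beyond the scatter) and provides the first comparison here in which only one place changes, showing that growth inhibition responds to the group at this position, though only modestly. The exchange alters several things at once, since the entering group has fewer heavy atoms and one hydrogen-bond donor where the leaving group has none, so this single step cannot separate their contributions. Nothing measured here accounts for the lower number.

Still open, as far as these compounds go, is which part of the exchange matters: a plain phenyl, or a phenyl carrying a single methoxy or an amine, on the same nitrogen with the rest of the molecule unchanged, would help to separate the loss of the methoxy groups from the gain of the hydroxyl. From the compounds shown here alone, it is also open whether this step would keep its direction and size with a different chain on the shared core, such as a longer alkyl chain.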